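The source may hold more compounds than are shown below. What is called first, only, known or untested is meant among the compounds shown, and "the series" means these compounds.

Three compounds of one series have been run in a functional assay on HEK293 cells for agonist activity at Free fatty acid receptor 1 (Homo sapiens), read by calcium flux; on this read-out higher numbers stand for an effect only at larger amounts of compound and lower numbers for an effect already at smaller amounts. Compound 1 `CCCCCOc1ccc(C(CC(=O)O)c2ccccc2)cc1` gives 2.97 uM there, and compound 2 `CCCCCCOc1ccc(C(CC(=O)O)c2ccccc2)cc1` gives 2.88 uM. The change between them is methyl in place of hydrogen on a saturated chain carbon, five bonds along the chain from an oxygen on an aromatic ring, and it made a 1.0-fold lower number from compound 1 to compound 2 (0.01 log units; within the scatter). Compound 3 `CCC(C)COc1ccc(C(CC(=O)O)c2ccccc2)cc1` gives 0.3 uM; its core differs from that of compound 1 by sec-butyl in place of butyl on a saturated chain carbon bound to an oxygen on an aromatic ring, a rearrangement that made a 9.9-fold lower number from compound 1 to compound 3 (1.00 log units; beyond the scatter), and against compound 2 the gap is a 9.6-fold lower number from compound 2 to compound 3 (0.98 log units; beyond the scatter).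

Compound 4 `CCC(CC)COc1ccc(C(CC(=O)O)c2ccccc2)cc1` has not yet been measured. It differs from compound 3 by methyl in place of hydrogen on a saturated chain carbon, three bonds along the chain from an oxygen on an aromatic ring. For the measured compounds named here, this is the same kind of change as the one from compound 1 to compound 2, but not the same: there the added methyl sits five bonds along the chain from the oxygen on the aromatic ring, here only three bonds along it. Since the earlier addition of a methyl left the number flat, compound 4 is expected to stay close to compound 3, with an estimated step of a 1.3-fold higher number from compound 3 to compound 4 (0.12 log units; within the scatter). On that basis compound 4 is estimated at 0.4 uM in this assay, within a range from 0.15 uM to 1.2 uM.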

Compound 4, concentration for half-maximal effect: 0.64 uM
Compound 4: the middle estimate sits 1.6-fold (0.20 log units) below what was measured; measured number inside the range.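

In this assay the added methyl gave a 2.1-fold higher number from compound 3 to compound 4 (0.33 log units; beyond the scatter), and the pentan-3-yl chain still left lower numbers than the pentyl and butyl chains, with a 4.5-fold lower number from compound 2 to compound 4 (0.65 log units; beyond the scatter) and a 4.6-fold lower number from compound 1 to compound 4 (0.67 log units; beyond the scatter). For the compounds shown here, this does not show that the change carries over unchanged: there is only one pair of steps, and the added methyl sits five bonds along the chain from the oxygen in one and three bonds along it in the other. Set side by side, the two methyl additions give no ground for saying that the change acts differently on the two cores: the same change on two cores in this assay, a 1.0-fold lower number (0.01 log units; within the scatter) from compound 1 to compound 2 and a 2.1-fold higher number (0.33 log units; beyond the scatter) from compound 3 to compound 4, 2.2-fold (0.34 log units) apart, within the scatter of two such steps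

The compounds shown leave open how a methyl placed elsewhere on these chains, a longer branched chain or a cyclopropylmethyl group would read. They also leave open whether the same change would hold with a tetrazole in place of the carboxylic acid.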